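This account rests on a few compounds, and the source may have more. Where it says the series, first, only, none or still open, it means among the compounds named here.

Among the compounds with values here, in a functional assay on A549 cells (Homo sapiens) for cytotoxicity, read by MTT assay, with a stated time of 72 h (on this read-out higher numbers stand for weaker inhibition and lower numbers for stronger inhibition), compound 3 `O=C(/C=C/c1cc(Br)c(O)c(Br)c1)Nc1cc2c(Nc3ccc(F)c(Cl)c3)ncnc2cc1O[C@H]1CCOC1` gives 28800 nM, the second highest of the three numbers measured so far; compound 2 `O=C(/C=C/c1ccc(Br)cc1)Nc1cc2c(Nc3ccc(F)c(Cl)c3)ncnc2cc1O[C@H]1CCOC1` gives 35300 nM and compound 1 `O=C(/C=C/c1cccc(Cl)c1Cl)Nc1cc2c(Nc3ccc(F)c(Cl)c3)ncnc2cc1O[C@H]1CCOC1` gives 23200 nM, and both values sit within the scatter of compound 3. Compound 4 `O=C(/C=C/c1ccccc1[N+](=O)[O-])Nc1cc2c(Nc3ccc(F)c(Cl)c3)ncnc2cc1O[C@H]1CCOC1` differs from compound 3 in one place: 2-nitrophenyl in place of 3,5-dibromo-4-hydroxyphenyl on a double-bonded chain carbon bound to a double-bonded chain carbon. Within the data shown here, the steps that bear on this swap are a 1.2-fold higher number from compound 1 to compound 3 (0.09 log units; within the scatter), a 1.2-fold lower number from compound 2 to compound 3 (0.09 log units; within the scatter) and a 1.5-fold higher number from compound 1 to compound 2 (0.18 log units; within the scatter), each within the scatter, so three different aryl groups on a double-bonded chain carbon bound to a double-bonded chain carbon have left this assay essentially unchanged. A step of about a 1.0-fold lower number from compound 3 to compound 4 (0.01 log units; within the scatter) is therefore expected, with no direction beyond the scatter. For compound 4 the expected value in this assay is 28000 nM, within a range from 12000 nM to 65000 nM.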

Compound 4, half-maximal inhibitory concentration: 8820 nM
The estimate for compound 4 lay 3.2-fold (0.50 log units) above the measured number, and the stated range ends above it.
By their numbers in this assay, from the lowest: compound 4; then compounds 1, 3 and 2 (each within the scatter of the next).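

In this assay, the aryl group on a double-bonded chain carbon bound to a double-bonded chain carbon can move the number after all: 2-nitrophenyl gives a 3.3-fold lower number from compound 3 to compound 4 (0.51 log units; beyond the scatter) and a 4.0-fold lower number from compound 2 to compound 4 (0.60 log units; beyond the scatter) and a 2.6-fold lower number from compound 1 to compound 4 (0.42 log units; beyond the scatter). Among the compounds shown, this position therefore separates 2-nitrophenyl from the three halogen-bearing aryl groups, which stay within the scatter of one another. Nothing available explains this difference.

As far as these compounds go, whether the lower number comes from the nitro group or from the absence of halogen stays open. How an amine or a carboxylic acid on that phenyl ring would compare is also unknown.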